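The compounds below may be only part of what the source reports. "The series", "measured", "known", "first", "only" and "open" are said of these compounds alone.

Compound 1 `COc1ccc(NS(=O)(=O)/C=C/c2c(OC)cc(OC)cc2OC)cc1`: 25 nM
Compound 2 `COc1cc(OC)c(/C=C/S(=O)(=O)Nc2ccc(OC)c(O)c2)c(OC)c1`: 10 nM

Among the measured compounds shown here, in a functional assay on RF48 cells (Homo sapiens) for cytotoxicity, read by trypan blue exclusion, with a stated time of 96 h (on this read-out lower numbers stand for stronger inhibition of growth and higher numbers for weaker inhibition of growth), compound 2 stands at the lowest of the two numbers; the single measured step, a 2.5-fold lower number from compound 1 to compound 2 (0.40 log units; beyond the scatter), is modest. Compound 3 `COc1cc(OC)c(/C=C/S(=O)(=O)Nc2ccc(OC)c(N)c2)c(OC)c1` differs from compound 2 by amino in place of hydroxy on an aromatic carbon. For the measured compounds named here, no measured step swaps hydroxy for amino, so the hydrogen-to-hydroxy step is only a loose guide: it shows that this position tolerates a donor-acceptor group, but says nothing on amino against hydroxy. The step expected in this assay is therefore a 1.8-fold higher number from compound 2 to compound 3 (0.26 log units; within the scatter), within or only just beyond the scatter, leaning toward a higher number. Compound 3 is estimated at 18 nM, range 6 nM to 55 nM.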

Compound 3, concentration for 50% growth inhibition: 4 nM
The estimate for compound 3 lay 4.5-fold (0.65 log units) above the measured number; the measured number lies below the stated range.
By their numbers in this assay, from the lowest: compound 3; then compound 2; then compound 1.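

At this position, ortho to a methoxy group, the choice of donor-acceptor group matters and not just its presence: in this assay amino in place of hydroxy gives a 2.5-fold lower number from compound 2 to compound 3 (0.40 log units; beyond the scatter) and stands out further against hydrogen, with a 6.3-fold lower number from compound 1 to compound 3 (0.80 log units; beyond the scatter) beyond the scatter. The number thus falls in the order hydrogen, hydroxy, amino across these three compounds. No data on hand bear on the reason for this order.

Open, going by these compounds, is whether an acetamide, a methylamino group or a carboxylic acid here would continue that order. Also open, on these data alone, is whether amino keeps its edge over hydroxy elsewhere on this ring.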